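This account rests on a few compounds, and the source may have more. Where it says the series, first, only, none or still open, it means among the compounds named here.

Measured compounds:
compound 1, `O=C(O)CCCOc1cc(-c2ccccc2)cc(-c2ccccc2)n1`, 300 nM
compound 2, `CC(CCCCOc1cc(-c2ccccc2)cc(-c2ccccc2F)n1)C(=O)O`, 4 nM
compound 3, `CC(C)(CCCCOc1cc(-c2ccc(N)cc2)cc(-c2ccccc2)n1)C(=O)O`, 6.6 nM

In an assay on cell membranes from spleen (Cavia porcellus) for binding affinity to leukotriene B4 receptor 1 (Homo sapiens) (a lower number here means a stronger inhibitor, a higher number a weaker inhibitor), compound 1 gives 300 nM, the highest of the three numbers and therefore the weakest binder shown. Compound 2 gives 4 nM and compound 3 gives 6.6 nM, both far beyond the scatter below compound 1; each of them differs from compound 1 in more than one place, so no single step can be read from them.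

Compound 4, `NC(=O)CCCCCOc1cc(-c2ccccc2)cc(-c2ccccc2)n1`, is the next candidate. Relative to compound 1 the change is 2-carbamoylethyl in place of carboxy on a saturated chain carbon, three bonds along the chain from an oxygen on an aromatic ring. Every measured compound in the series carries a free acid on the chain; nothing measured yet reports what happens when the acid is replaced by a primary amide, nor what the longer chain alone contributes. Among the compounds with values here, no step between measured compounds covers this change. The expectation is a weakening step beyond the scatter, estimated as a 5.0-fold higher number from compound 1 to compound 4 (0.70 log units; beyond the scatter) in this assay. For compound 4 the estimate in this assay is 1500 nM, with a range from 300 nM to 8000 nM.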

Compound 4, half-maximal inhibitory concentration: 160 nM
Compound 4: middle estimate off by 9.4-fold (0.97 log units), on the high side; the whole stated range lies above it.
By their numbers in this assay, from the lowest: compounds 2 and 3 (each within the scatter of the next); then compounds 4 and 1 (each within the scatter of the next).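

In this assay, 2-carbamoylethyl in place of carboxy on a saturated chain carbon, three bonds along the chain from an oxygen on an aromatic ring, gives a 1.9-fold lower number from compound 1 to compound 4 (0.27 log units; within the scatter). Within the data shown here, compound 4 is the first compound without a carboxylic acid, so a free acid at this position is not needed for binding in the range of compound 1, though the step joins the primary amide with a longer chain and cannot be divided between them. Nothing at hand gives a reason for this result.

Still open, as far as these compounds go, are the carboxylic acid on the chain of compound 4 and the primary amide on the chain of compound 1, either of which would separate the two parts of the change. Also open, from the compounds shown here alone, is whether a primary amide in place of the carboxylic acid would hold the numbers of compound 2 at 4 nM and compound 3 at 6.6 nM.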